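This account rests on a few compounds, and the source may have more. Where it says the series, first, only, none or still open, it means among the compounds named here.

In a functional assay (aorta) for inhibition, with Rattus norvegicus as the target (on this read-out lower numbers stand for stronger inhibition and higher numbers for weaker inhibition), compound 1 `C/N=C(/S)[C@]1(c2cccnc2)CCCC[S@@+]1[O-]` gives 700 nM; 400 nM; > 30000 nM (3 entries) as separate entries. One entry of compound 1 carries a sign and is a limit of the assay, not a number. Compound 2 `C/N=C(\S)[C@]1(c2cnc3ccccc3c2)CCCC[S+]1[O-]` reads 60 nM and compound 3 `C/N=C(\S)[C@]1(c2cccc(C#N)c2)CCCC[S+]1[O-]` reads 1600 nM as the higher of these two numbers, a gap beyond the scatter, so compound 3 is the weaker inhibitor of this pair. Compound 4 `C/N=C(\S)[C@]1(c2cccc(C(=O)O)c2)CCCC[S+]1[O-]` carries carboxy in place of cyano on an aromatic carbon, meta to a large group (carboxy in place of cyano on an aromatic carbon). Among the compounds with values here, no measured pair isolates this exchange, so its size rests on judgement. The expected step is a 5.0-fold higher number from compound 3 to compound 4 (0.70 log units; beyond the scatter) towards weaker inhibition, beyond the scatter. For compound 4 the estimate is 8000 nM with an expected range from 1500 nM to 30000 nM on this read-out.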

Compound 4, concentration for 90% inhibition: > 30000 nM
Compound 4: a limit, no number; the forecaster's own chance of this, stated with the estimate: 30%; at least 3.7-fold (0.57 log units) between middle value and limit.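

In this assay, carboxy in place of cyano on an aromatic carbon, meta to a large group, gives a large loss of inhibition: an at least 18-fold higher number from compound 3 to compound 4 (1.27 log units; beyond the scatter). Compound 4 gives > 30000 nM, which is a limit of the assay and not a number, so the step has a floor but no upper end. Within the data shown here, this is the only single-place step, and it shows that this position does not tolerate every substituent exchange.

Open, from the compounds shown here alone, is how a primary amide or a methyl ester at this position would read. Also open, going by these compounds, is whether the same exchange would give a similar step on another core.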